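The compounds below may be only part of what the source reports. "The series", "measured", "known", "first", "only" and "open" are said of these compounds alone.

Series notes. Three compounds of the shared core have numbers in a functional assay on HCT-116 cells (Homo sapiens) for antiproliferative activity; a lower number here means a stronger inhibitor, a higher number a weaker inhibitor. Compound 1 `CO/N=C/c1c(N)ncnc1Oc1ccc2cccnc2c1` gives 2620 nM. Among the measured compounds shown here, compound 2 `CNCCO/N=C/c1c(N)ncnc1Oc1ccc2[nH]c(C)cc2c1F` gives 3010 nM, the highest of the three numbers so far; its nearest neighbour is compound 1, and the two sit within the scatter of each other, so no order between them is claimed. Compound 3 `CO/N=C/c1c(N)ncnc1Oc1cc2cc[nH]c2cc1F` gives 422 nM, and the gap from compound 2 to compound 3 lies beyond the scatter.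

Compound 4 `Cc1cc2c(F)c(Oc3ncnc(N)c3/C=N/OCCO)ccc2[nH]1` is not yet measured. It differs from compound 2 in one place: hydroxy in place of methylamino on a saturated chain carbon, two bonds along the chain from an oxygen on an unsaturated carbon. For the measured compounds named here, no measured pair in this set shares that change, so the data show neither its size nor its direction. The shared core, the ether link and the chain itself are kept; only the group on the chain carbon is exchanged. With nothing to anchor a shift, the step of a 1.2-fold higher number from compound 2 to compound 4 (0.07 log units; within the scatter) is expected to stay within the scatter, in either direction. Compound 4 is estimated at 3500 nM, with a range from 1200 nM to 10000 nM.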

Compound 4, half-maximal inhibitory concentration: 323 nM
Compound 4: middle estimate off by 11-fold (1.03 log units), on the high side; the measured number lies below the stated range.
By their numbers in this assay, from the lowest: compounds 4 and 3 (each within the scatter of the next); then compounds 1 and 2 (each within the scatter of the next).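

Among the compounds shown here, this is the first pair that differs in one place, and it shows that the group on this saturated chain carbon, two bonds along the chain from an oxygen on an unsaturated carbon, matters in this assay: hydroxy in place of methylamino gives a 9.3-fold lower number from compound 2 to compound 4 (0.97 log units; beyond the scatter). The hydrogen-bond donor and acceptor counts are the same for the group leaving and the group entering, so these counts do not separate the two groups. Nothing at hand bears on why the number moves.

Going by these compounds, whether the same exchange has a similar effect on the cores of compound 1 or compound 3 stays open, as this is one pair on one background. Also open, on these data alone, is how a dimethylamino group, a carboxylic acid or a longer chain ending in hydroxy would read at this place.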